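Swapping a thiophene sulfonyl group for a methoxyphenyl one

The compounds below may be only part of what the source reports. "The series", "measured", "known", "first", "only" and "open" are said of these compounds alone.

Measured so far in an ADME assay on HEK293 cells (Homo sapiens) for cytotoxicity, read by resazurin assay, with a stated time of 48 h; on this read-out higher numbers stand for lower toxicity in this test and lower numbers for higher toxicity in this test:
- compound 1, `O=S(=O)(Nc1ccc(-c2nc3ccccc3o2)cc1)c1cccs1`: > 100000 nM 
- compound 2, `Cc1cccc(S(=O)(=O)Nc2ccc3oc(-c4ccccc4)nc3c2)c1`: 69000 nM 
- compound 3, `O=[N+]([O-])c1cc(S(=O)(=O)Nc2ccc3oc(-c4ccccc4)nc3c2)ccc1Cl`: 90000 nM 

All three compounds are aryl sulfonamides built on the same shared core, and the question here is how far the cells tolerate them. For compound 1 the result in this assay is not a number but a limit of the assay, > 100000 nM, so its true value is known only as lying at or past that point; this is recorded as the limit of > 100000 nM in this assay, at which 1 of the 3 values shown sits. Compound 2 and compound 3 carry their sulfonamide on a different part of the core, so their values in this assay, where compound 2 gives 69000 nM and compound 3 gives 90000 nM, cannot be read as steps from compound 1, and they show only that this family tends to sit at the low-toxicity end of the scale.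

The new compound 4, `COc1cccc(S(=O)(=O)Nc2ccc(-c3nc4ccccc4o3)cc2)c1`, changes one thing: 3-methoxyphenyl in place of thiophen-2-yl on a sulfonyl sulfur. Since compound 1 sits at the limit, any step can only be estimated loosely. The expectation is a step of about an at least 1.1-fold lower number from compound 1 to compound 4 (0.04 log units; that floor lies within the scatter), which is within the usual scatter and in no particular direction. Compound 4 is therefore estimated at 90000 nM, with a plausible range from 35000 nM to 200000 nM in this assay.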

Compound 4, half-maximal cytotoxic concentration: > 100000 nM
Compound 4: a limit, no number (the forecaster's own chance of this, stated with the estimate: 50%); at least 1.1-fold (0.04 log units) between middle value and limit.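

In this assay compound 4, like compound 1, ends at a limit of the assay and not at a number, so no step can be read between the two: the limit of > 100000 nM in this assay, at which 2 of the 4 values shown sit.

The compounds shown leave open how far past that limit each one lies, and whether 3-methoxyphenyl in place of thiophen-2-yl changes toxicity in these cells at all.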